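The source may report more compounds than this note shows. Statements on the series, on what has been measured and on what is new or still open speak of the compounds shown alone.

Of the compounds shown here, two of a shared core have been measured in an assay on isolated protein for displacement of a labelled ligand from 5-hydroxytryptamine receptor 6 (Homo sapiens); a higher number here means a weaker inhibitor, a lower number a stronger inhibitor. Compound 1 `CC(=N)NCC1CCCc2cc(S(=O)(=O)c3ccccc3)ccc21` gives 0.631 nM. Compound 2 `CN(C[C@@H]1CCCc2cc(S(=O)(=O)c3cccc(F)c3)ccc21)S(N)(=O)=O` gives 3.98 nM, the higher of the two numbers, and its gap to compound 1 lies beyond the scatter. Compound 3 `CN(C)S(=O)(=O)NC[C@@H]1CCCc2cc(S(=O)(=O)c3cccc(F)c3)ccc21` differs from compound 2 in one place: (dimethylsulfamoyl)amino in place of methyl(sulfamoyl)amino on a saturated chain carbon bound to a saturated ring carbon. Going by the values given here, no measured pair shows this change, so only a small step is expected, if any beyond the scatter, in either direction. The step from compound 2 to compound 3 is estimated at a 1.3-fold higher number from compound 2 to compound 3 (0.10 log units; within the scatter). For compound 3 the expected value in this assay is 5 nM, within a range of 1.5 nM to 16 nM.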

Compound 3, inhibition constant: 2 nM
Compound 3: the middle estimate sits 2.5-fold (0.40 log units) above what was measured, within the range that was stated.
By their numbers in this assay, from the lowest: compound 1; then compounds 3 and 2 (each within the scatter of the next).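

In this assay, putting (dimethylsulfamoyl)amino in place of methyl(sulfamoyl)amino on a saturated chain carbon bound to a saturated ring carbon gives a 2.0-fold lower number from compound 2 to compound 3 (0.30 log units; within the scatter), so this position takes the group with one more carbon without a step beyond the scatter. Nothing measured bears on what lies behind this step. The compounds shown leave open whether this position would tolerate a group of another kind, such as a primary amine or a carboxylic acid, and what a longer chain on the sulfamoyl nitrogen would do.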